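Working notes: from compound 3 to compound 4

The source may report more compounds than this note shows. Statements on the series, on what has been measured and on what is new or still open speak of the compounds shown alone.

In a functional assay on HepG2 cells (Homo sapiens) for inhibition, read by MTT assay, with a stated time of 48 h (on this read-out higher numbers stand for weaker inhibition and lower numbers for stronger inhibition), compound 1 `CCOC(=O)C1=C(NN=C(C#N)C#N)Nc2[nH]nc(C)c2C1c1ccc(N(C)C)cc1` gives 13700 nM, compound 2 `CCOC(=O)C1=C(N/N=C(/Cl)c2ccc([N+](=O)[O-])cc2)Nc2[nH]nc(C)c2C1c1ccc(N(C)C)cc1` gives 55500 nM and compound 3 `CCOC(=O)C1=C(N/N=C(/Br)c2ccccc2)Nc2[nH]nc(C)c2C1c1ccc(N(C)C)cc1` gives 72000 nM. Compound 3 stands at the high end of these numbers, together with compound 2. The gap within that pair is a 1.3-fold higher number from compound 2 to compound 3 (0.11 log units; within the scatter).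

The change to compound 4 `CCOC(=O)C1=C(N/C=N/c2ccccn2)Nc2[nH]nc(C)c2C1c1ccc(N(C)C)cc1` is a group of 8 heavy atoms (6 carbon, 2 nitrogen; one six-membered aromatic ring with 1 hetero atom) in place of a group of 9 heavy atoms (7 carbon, 1 nitrogen, 1 bromine; one six-membered aromatic ring of carbon only), on an amine nitrogen, on an amine nitrogen. The two steps away from the group with no ring are a 4.1-fold higher number from compound 1 to compound 2 (0.61 log units; beyond the scatter) and a 5.3-fold higher number from compound 1 to compound 3 (0.72 log units; beyond the scatter). Both are modest, and only compound 1 lies apart. For the measured compounds named here, compound 4 keeps a six-membered aromatic ring, now with 1 hetero atom, and no measured compound tests such a ring directly.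

The expectation therefore follows the pair with rings, which differ by a 1.3-fold higher number from compound 2 to compound 3 (0.11 log units; within the scatter), with a small downward lean at most. The expected change is a 1.4-fold lower number from compound 3 to compound 4 (0.16 log units; within the scatter), so no step beyond the scatter is expected. For compound 4 the estimated value in this assay is 50000 nM, with an estimated range of 18000 nM to 130000 nM.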

Compound 4, half-maximal inhibitory concentration: 26200 nM
Compound 4: the middle estimate sits 1.9-fold (0.28 log units) above what was measured, and the stated range covers the measured number.
By their numbers in this assay, from the lowest: compounds 1 and 4 (each within the scatter of the next); then compounds 2 and 3 (each within the scatter of the next).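

In this assay, this place on the amine nitrogen now separates groups that all carry a six-membered aromatic ring (a 2.7-fold lower number from compound 3 to compound 4 (0.44 log units; beyond the scatter) and a 2.1-fold lower number from compound 2 to compound 4 (0.33 log units; beyond the scatter)), and both steps lie beyond the scatter, so the presence of such a ring does not alone set the number. The group with a six-membered aromatic ring with 1 hetero atom also stands within the scatter of the group with no ring (a 1.9-fold higher number from compound 1 to compound 4 (0.28 log units; within the scatter)), so the earlier split between compound 1 and the ring-bearing compounds does not hold for compound 4. No measured evidence bears on a cause for these steps.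

Compound 4 differs from compound 2 and compound 3 in more than the ring, so the hetero atom and the rest of the entering group cannot be told apart here. A phenyl ring on the same chain would separate the two, and an amine or carboxylic acid on the ring remains an open case.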